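Tertiary alcohol from secondary: methyl on the carbinol carbon

This account rests on a few compounds, and the source may have more. Where it says the series, first, only, none or still open, it means among the compounds named here.

Compound 2 `CCCCCC(O)CN` gives 314000 nM in an assay on isolated protein for inhibition of Phenylethanolamine N-methyltransferase (Bos taurus) (on this read-out lower numbers stand for stronger inhibition and higher numbers for weaker inhibition), and stands second highest of the three numbers: compound 1 `CCCCC(O)CN` gives 345000 nM, within the scatter of compound 2, while compound 3 `CCCCCCC(O)CN` gives 109000 nM, the furthest. The measured steps all lengthen the chain: a 1.1-fold lower number from compound 1 to compound 2 (0.04 log units; within the scatter), a 3.2-fold lower number from compound 1 to compound 3 (0.50 log units; beyond the scatter) and a 2.9-fold lower number from compound 2 to compound 3 (0.46 log units; beyond the scatter). Compound 4 `CCCCCC(C)(O)CN` differs from compound 2 by methyl in place of hydrogen on a saturated chain carbon bound to an oxygen on a saturated carbon and two saturated chain carbons. Among the measured compounds shown here, no measured step touches the carbon bound to the oxygen, so none bears directly on this change; the chain steps only show that small additions move this read-out modestly at most. For compound 4 a step within the scatter is therefore expected, a 1.0-fold lower number from compound 2 to compound 4 (0.02 log units; within the scatter), and the estimate is 300000 nM with a range of 120000 nM to 800000 nM.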

Compound 4, half-maximal inhibitory concentration: 669000 nM
The estimate for compound 4 lay 2.2-fold (0.35 log units) below the measured number, and the stated range covers the measured number.
By their numbers in this assay, from the lowest: compound 3; then compounds 2, 1 and 4 (each within the scatter of the next, the first and the last beyond it).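

Methyl in place of hydrogen on a saturated chain carbon bound to an oxygen on a saturated carbon and two saturated chain carbons gives, in this assay, a 2.1-fold higher number from compound 2 to compound 4 (0.33 log units; beyond the scatter). Among the compounds shown here, this is the first step toward a higher number beyond the scatter, while added carbon further along the chain gave either no step beyond the scatter or a lower number, so this position responds differently. No supporting data explain the difference.

Going by these compounds, whether ethyl at this carbon moves the number the same way remains open. So does whether this methyl has the same effect on a longer chain.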